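Fluoro in Place of Amino: Outlook for Compound 4

The compounds below may be only part of what the source reports. "The series", "measured", "known", "first", "only" and "open" are said of these compounds alone.

Three compounds have so far been examined in a functional assay on A549 cells (Homo sapiens) for antiproliferative activity, read by MTT assay, with a stated time of 72 h; a lower number here means a stronger inhibitor, a higher number a weaker inhibitor: compound 1 `COc1ccccc1-c1ncnn1-c1cc(OC)c(OC)c(OC)c1`, compound 2 `COc1cc(-c2ncnn2-c2cccc(N)c2)cc(OC)c1OC` and compound 3 `COc1cc(-n2ncnc2-c2ccc(OC(F)(F)F)cc2)cc(OC)c1OC`. None of them returned a number. Compound 1 gives > 10000 nM in this assay, which is a limit rather than a measured value. Compound 2 gives > 10000 nM, again a limit. Compound 3 likewise gives > 10000 nM, a limit. Compound 2 therefore stands no differently from its two companions; the three share (the limit of > 10000 nM in this assay, at which 3 of the 3 values shown sit). Every measured compound sits at this limit. Going by the values given here, no step between measured compounds can be computed, and nothing in the set ranks one compound against another.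

Compound 4 `COc1cc(-c2ncnn2-c2cccc(F)c2)cc(OC)c1OC` has not yet been measured. It differs from compound 2 in one place: fluoro in place of amino on an aromatic carbon. Among the compounds with values here, with no measured step to weigh the change against, the expected step that the limit leaves unreadable from compound 2 to compound 4 is none beyond the scatter, and compound 4 is expected most likely to be reported as a limit once more. Compound 4 is estimated at 15000 nM, within a range from 5000 nM to 50000 nM.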

Compound 4, half-maximal inhibitory concentration: > 10000 nM
Compound 4: a limit, no number (the forecaster's own chance of this, stated with the estimate: 85%); the middle value does not contradict the limit.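

Going by these compounds alone, compound 4, like compound 2, gives only a limit in this assay, so no step between compound 2 and compound 4 can be read. The compounds shown leave open how active any of them is and whether fluoro in place of amino changes that activity at all.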